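Para-substituent swap on the cyclohexylamino imidazopyridine series

The compounds below may be only part of what the source reports. "The series", "measured", "known", "first", "only" and "open" are said of these compounds alone.

Measured so far:
- compound 1 `O=[N+]([O-])c1ccc(-c2nc3ccccn3c2NC2CCCCC2)cc1`: > 100000 nM
- compound 2 `Nc1c(-c2ccccc2)nc2ccccn12`: > 100000 nM

Compound 1 has no number in an assay on membranes from brain for displacement of a labelled ligand from adenosine receptor A1 (Rattus norvegicus) (a higher number here means a weaker inhibitor, a lower number a stronger inhibitor), but only a limit, > 100000 nM. Compound 2 likewise sits at a limit in this assay, > 100000 nM. Among the measured compounds shown here, both values shown therefore rest at the same point, (the limit of > 100000 nM in this assay, at which 2 of the 2 values shown sit), so compound 1 stands nowhere in particular: it is unplaced within the window of the assay, and no measured step exists against which to set the coming change.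

Compound 3 `Clc1ccc(-c2nc3ccccn3c2NC2CCCCC2)cc1` differs from compound 1 in one place: chloro in place of nitro on an aromatic carbon. For the measured compounds named here, with no measured step in hand, the expectation for compound 3 rests on compound 1 alone, whose value is a limit, (the limit of > 100000 nM in this assay, at which 2 of the 2 values shown sit); a step beyond the scatter in either direction cannot be asserted. Compound 3 is estimated at 100000 nM, within 20000 nM to 500000 nM, so the step from compound 1 to compound 3 is expected to be a number no higher from compound 1 to compound 3 (the limit leaves the size open), and a limit rather than a number remains the likelier outcome for compound 3.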

Compound 3, inhibition constant: > 100000 nM
Compound 3 ended at the assay's limit (the forecaster's own chance of this, stated with the estimate: 70%); the middle value lies on the limit itself.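

Compound 1 and compound 3 both rest at a limit in this assay, so no step can be read for chloro in place of nitro: the limit of > 100000 nM in this assay, at which 3 of the 3 values shown sit.

The compounds shown leave open how chloro and nitro compare in this assay, and what change to the core of compound 1 would give a number rather than a limit.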